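Bromo to nitro exchange in a small cytotoxicity series

A few compounds are considered here, and "the series" means these few. Any claim that something is new, unique, unknown or untested is made for them only; others in the source may bear on it.

Measured so far in an ADME assay on Huh-7 cells (Homo sapiens) for cytotoxicity, read by MTT assay, with a stated time of 72 h; on this read-out lower numbers stand for higher toxicity in this test and higher numbers for lower toxicity in this test:
compound 1, `O=C(NO)c1ccccc1Br`, gives 270000 nM
compound 2, `O=C(NO)c1ccccc1[N+](=O)[O-]`, gives 55000 nM
compound 3, `O=C(NO)c1cccc(Br)c1`, gives 310000 nM

Compound 1 and compound 3 have the same atoms joined differently; the difference between the two cores is not broken down here, and their values lie within the scatter of one another. Compound 2 differs from compound 1 by nitro in place of bromo on an aromatic carbon, and this gave a 4.9-fold lower number from compound 1 to compound 2 (0.69 log units; beyond the scatter).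

Compound 4, `O=C(NO)c1cccc([N+](=O)[O-])c1`, is not yet measured. It differs from compound 3 by nitro in place of bromo on an aromatic carbon. This is the same kind of change as that from compound 1 to compound 2, but the place is not identical: in compound 2 the nitro sits ortho to a group of 4 heavy atoms, in compound 4 meta to a group of 4 heavy atoms.

Within the data shown here, for compound 4 in this assay a step of a 4.8-fold lower number from compound 3 to compound 4 (0.68 log units; beyond the scatter) is expected, resting on the single earlier instance, where compound 1 to compound 2 gave a 4.9-fold lower number from compound 1 to compound 2 (0.69 log units; beyond the scatter). Among the measured compounds shown here, only one example supports this, so the range is kept wide. Compound 4 is estimated at 65000 nM, between 25000 nM and 170000 nM.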

Compound 4, half-maximal cytotoxic concentration: 160000 nM
Estimate against measurement, compound 4: 2.5-fold (0.39 log units) below; the measured number falls inside the stated range.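

In this assay nitro in place of bromo on an aromatic carbon gives a 1.9-fold lower number from compound 3 to compound 4 (0.29 log units; within the scatter) and, taken alone, this step on the core of compound 3 is not resolved from repeat-measurement noise. Set beside the earlier step on the core of compound 1, the change does not separate the two cores: the same change on two cores in this assay, a 4.9-fold lower number (0.69 log units; beyond the scatter) from compound 1 to compound 2 and a 1.9-fold lower number (0.29 log units; within the scatter) from compound 3 to compound 4, 2.5-fold (0.40 log units) apart, within the scatter of two such steps. Both steps run in the same direction, so the data are compatible with the change carrying over between these cores, but two pairs do not show that it transfers with a fixed size, nor do they show that the two steps are truly equal or say what lies behind either of them.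

Still open, as far as these compounds go, is whether an amine, a nitrile or a carboxylic acid on the same aromatic carbon would fall nearer to bromo or to nitro in this test. Also open, from the compounds shown here alone, is whether the change from bromo to nitro would hold on any core beyond these two.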